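The source may report more compounds than this note shows. Statements on the series, on what has been measured and on what is new or still open speak of the compounds shown alone.

Compound 1 `N[C@H]1CC[C@@H](Oc2ccc([C@H]3CC[C@]4(CC3)OOC3(O4)C4CC5CC(C4)CC3C5)cc2)CC1` carries a 4-aminocyclohexyl group on an oxygen on an aromatic ring. In an ADME assay on microsomes from liver (Homo sapiens) for metabolic stability, read by LC-MS, tested at 1 uM (on this read-out higher numbers stand for fast clearance and lower numbers for slow clearance), compound 1 gives < 7 mL.min-1.g-1, which is a limit of the assay and not a number. Compound 2 `NCCCOc1ccc([C@H]2CC[C@]3(CC2)OOC2(O3)C3CC4CC(C3)CC2C4)cc1` likewise sits at a limit, giving < 7 mL.min-1.g-1 in this assay. Compound 3 `c1cc([C@H]2CC[C@]3(CC2)OOC2(O3)C3CC4CC(C3)CC2C4)ccc1OCCC1CCNCC1` also returns a limit, < 7 mL.min-1.g-1. Because of this (the limit of < 7 mL.min-1.g-1 in this assay, at which 3 of the 3 values shown sit), the steps a step that the two limits leave unreadable from compound 1 to compound 2 and a step that the two limits leave unreadable from compound 1 to compound 3 cannot be sized. Compound 4 `NCCS(=O)(=O)CCOc1ccc([C@H]2CC[C@]3(CC2)OOC2(O3)C3CC4CC(C3)CC2C4)cc1` differs from compound 1 by 2-((2-aminoethyl)sulfonyl)ethyl in place of 4-aminocyclohexyl on an oxygen on an aromatic ring. Those two steps bear on this change but give no readable size, so no step beyond the scatter is expected in this assay. Compound 4 is therefore estimated at 5 mL.min-1.g-1, between 2 mL.min-1.g-1 and 12 mL.min-1.g-1, a step that the limit leaves unreadable from compound 1 to compound 4 that is expected to leave it at the limit.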

Compound 4, intrinsic clearance in microsomes: 9 mL.min-1.g-1
Compound 4: middle estimate off by 1.8-fold (0.26 log units), on the low side; low and high end bracket the measured number.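

Among these compounds, compound 4 is the only compound here whose value in this assay is a number and not a limit, 9 mL.min-1.g-1. This turns unreadable comparisons into floors: an at least 1.2-fold higher number from compound 1 to compound 4 (0.10 log units; that floor lies within the scatter), an at least 1.2-fold higher number from compound 3 to compound 4 (0.10 log units; that floor lies within the scatter) and an at least 1.2-fold higher number from compound 2 to compound 4 (0.10 log units; that floor lies within the scatter). Each floor stays within the scatter, so no real change is shown at this position, and the true sizes and the steps among compounds 1, 2 and 3 cannot be read because of this: the limit of < 7 mL.min-1.g-1 in this assay, at which 3 of the 4 values shown sit.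

Still open, as far as these compounds go, is whether the value of compound 4 goes with the sulfonyl or with the amine. A thioether in place of the sulfonyl, or a carboxylic acid in place of the amine, would separate the two.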